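The source may hold more compounds than are shown below. What is called first, only, known or untested is meant among the compounds shown, and "the series" means these compounds.

Compounds measured:
compound 1, `COc1c(F)cccc1N1C(=O)CSC1c1cccc(C(=O)NCCCCc2ccccc2)c1` — 26.2 nM in a functional assay on HOS-TE85 cells (Homo sapiens) for inhibition, read by CCK-8 assay, with a stated time of 72 h; on this read-out higher numbers stand for weaker inhibition and lower numbers for stronger inhibition
compound 2, `O=C(NCCCCc1ccccc1)c1cccc(C2SCC(=O)N2c2ccc(C3CC3)cc2)c1` — 217 nM

Compound 2 stands with the highest number of the two; its nearest neighbour is compound 1, reached by an 8.3-fold higher number from compound 1 to compound 2 (0.92 log units; beyond the scatter). Compound 3, `O=C(NCCCCc1ccccc1)c1cccc(C2SCC(=O)N2c2ccccc2F)c1`, differs from compound 2 in one place: 2-fluorophenyl in place of 4-cyclopropylphenyl on an amide-type nitrogen in a ring. Among the compounds with values here, the only step that bears on this change is an 8.3-fold higher number from compound 1 to compound 2 (0.92 log units; beyond the scatter), which turned on the same amide-type nitrogen in the ring and was modest in size. Compound 3 is therefore expected to move back toward the number of compound 1, with a 3.1-fold lower number from compound 2 to compound 3 (0.49 log units; beyond the scatter). The estimate for compound 3 is 70 nM, within 25 nM to 200 nM.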

Compound 3, half-maximal inhibitory concentration: 34.1 nM
Beside the measured number, compound 3's estimate is 2.1-fold (0.31 log units) above it, and the stated range covers the measured number.
By their numbers in this assay, from the lowest: compounds 1 and 3 (each within the scatter of the next); then compound 2.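

In this assay, 2-fluorophenyl in place of 4-cyclopropylphenyl on the amide-type nitrogen in the ring gives a 6.4-fold lower number from compound 2 to compound 3 (0.80 log units; beyond the scatter) and so recovers most of the earlier loss. Set against 3-fluoro-2-methoxyphenyl, the same group gives a 1.3-fold higher number from compound 1 to compound 3 (0.11 log units; within the scatter) and cannot be told apart from it, so of the three groups only 4-cyclopropylphenyl stands apart. Nothing available explains this difference. On these data alone, whether a plain phenyl or a 4-fluorophenyl would fall with compound 3 or with compound 2 remains open, so the cyclopropyl group is not separated from its place on the phenyl ring.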